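The compounds below may be only part of what the source reports. "The series", "measured", "known", "first", "only" and "open" are said of these compounds alone.

Two compounds of a shared core, built around the structure `CC(Oc1ccnc(Nc2cnn(C)c2)c1)c1cccc(C(=O)NCc2cc(F)cc(F)c2)c1` for compound 2 and `COc1ccc(CNC(=O)c2cccc(C(C)Oc3ccnc(Nc4cnn(C)c4)c3)c2)cc1OC` for compound 1, have been examined in a functional assay on NCI-H3122 cells (Homo sapiens) for antiproliferative activity, read by MTT assay, with a stated time of 48 h; a higher number here means a weaker inhibitor, a lower number a stronger inhibitor. In this assay compound 1 gives 38500 nM, while compound 2 gives 7600 nM. Within the data shown here, the only measured step here, a 5.1-fold lower number from compound 1 to compound 2 (0.70 log units; beyond the scatter), concerns the same saturated chain carbon bound to an amide-type nitrogen that is now changed again. Among the measured compounds shown here, on these two numbers compound 2 stands lowest, with compound 1 the only neighbour and a clear gap between them.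

Compound 3, `CC(Oc1ccnc(Nc2cnn(C)c2)c1)c1cccc(C(=O)NCc2ccc(C#N)cc2)c1`, differs from compound 2 by 4-cyanophenyl in place of 3,5-difluorophenyl on a saturated chain carbon bound to an amide-type nitrogen. For the measured compounds named here, no measured step covers this particular swap; the step from compound 1 to compound 2 shows only that the aryl group at this position can move the number by a modest amount. For compound 3 the change is therefore expected to be small, and within or close to the scatter, with a slight drift toward a higher number as the more likely outcome, giving a 1.3-fold higher number from compound 2 to compound 3 (0.12 log units; within the scatter). Compound 3 is thus estimated at 10000 nM in this assay, with a plausible range from 3000 nM to 30000 nM.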

Compound 3, half-maximal inhibitory concentration: 35100 nM
For compound 3 the middle estimate is 3.5-fold (0.55 log units) below the measured one, and the stated range ends below it.
By their numbers in this assay, from the lowest: compound 2; then compounds 3 and 1 (each within the scatter of the next).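

In this assay, the aryl group on the saturated chain carbon bound to an amide-type nitrogen now has three measured members, and the 3,5-difluorophenyl of compound 2 is the one that stands apart. The new comparison, a 4.6-fold higher number from compound 2 to compound 3 (0.66 log units; beyond the scatter), is close in size to the earlier 5.1-fold lower number from compound 1 to compound 2 (0.70 log units; beyond the scatter), but it leads away from compound 2 rather than towards it, so the lower number is not shared by the other aryl group carrying a single substituent. With a 1.1-fold lower number from compound 1 to compound 3 (0.04 log units; within the scatter), the 4-cyanophenyl and 3,4-dimethoxyphenyl groups cannot be told apart here, and nothing measured alongside these numbers explains why compound 2 differs from both.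

On these data alone, whether the lower number of compound 2 follows from fluorine itself or from its arrangement in the 3,5-difluorophenyl group remains open, and an unsubstituted phenyl, a 4-fluorophenyl or a 3,5-dichlorophenyl on this carbon would bear on that. Also open, as far as these compounds go, is how an aminomethyl group or a carboxylic acid on the ring, or a longer chain in place of this single chain carbon, would compare with compound 2 at 7600 nM.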